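A few compounds are considered here, and "the series" means these few. Any claim that something is new, unique, unknown or untested is made for them only; others in the source may bear on it.

Three compounds sharing one core have numbers in an ADME assay on microsomes from liver (Homo sapiens) for metabolic stability, tested at 2.5 uM; on this read-out higher numbers stand for fast clearance and lower numbers for slow clearance. Compound 1 `Cc1ccc(S(=O)(=O)c2cnc3cc(F)ccc3c2-c2cccc(Cl)c2)cc1F` gives 2.13 mL/min; compound 2 `COc1cccc(S(=O)(=O)c2cnc3cc(F)ccc3c2-c2cccc(Cl)c2)c1` gives 2.97 mL/min; compound 3 `N#Cc1cccc(S(=O)(=O)c2cnc3cc(F)ccc3c2-c2cccc(Cl)c2)c1` gives 0.99 mL/min, the lowest of the three. The step of a 2.2-fold lower number from compound 1 to compound 3 (0.33 log units; beyond the scatter) and the step of a 3.0-fold lower number from compound 2 to compound 3 (0.48 log units; beyond the scatter) both lie beyond the scatter, whereas a 1.4-fold higher number from compound 1 to compound 2 (0.14 log units; within the scatter) stays within it. Compound 4 `COc1ccc(S(=O)(=O)c2cnc3cc(F)ccc3c2-c2cccc(Cl)c2)cc1Cl` carries 3-chloro-4-methoxyphenyl in place of 3-cyanophenyl on a sulfonyl sulfur. The entering group, like the groups on the sulfonyl sulfur of compound 1 and compound 2, holds no cyano, so the steps of a 2.2-fold lower number from compound 1 to compound 3 (0.33 log units; beyond the scatter) and a 3.0-fold lower number from compound 2 to compound 3 (0.48 log units; beyond the scatter) are expected to run back up for compound 4 in this assay. The expected step is a 2.5-fold higher number from compound 3 to compound 4 (0.40 log units; beyond the scatter). Compound 4 is thus estimated near 2.5 mL/min in this assay, with a range from 1.3 mL/min to 4.8 mL/min.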

Compound 4, intrinsic clearance in a liver preparation (reported as CLH), per the amount of preparation that the assay uses: 1.19 mL/min
For compound 4 the middle estimate is 2.1-fold (0.32 log units) above the measured one, and the stated range ends above it.
By their numbers in this assay, from the lowest: compounds 3, 4, 1 and 2 (each within the scatter of the next, the first and the last beyond it).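

With a 1.2-fold higher number from compound 3 to compound 4 (0.08 log units; within the scatter) in this assay, a group holding no nitrile reads level with 3-cyanophenyl on the sulfonyl sulfur, so the low end of this set is not tied to the nitrile. The same 3-chloro-4-methoxyphenyl group stands apart from 3-methoxyphenyl with a 2.5-fold lower number from compound 2 to compound 4 (0.40 log units; beyond the scatter), but not from 3-fluoro-4-methylphenyl with a 1.8-fold lower number from compound 1 to compound 4 (0.25 log units; within the scatter). Nothing at hand explains these steps. Open, from the compounds shown here alone, is which part of 3-chloro-4-methoxyphenyl carries the step from 3-methoxyphenyl, and how an amine or a carboxylic acid on this phenyl ring would read in this assay.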